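The source may report more compounds than this note shows. Statements on the series, on what has been measured and on what is new or still open speak of the compounds shown alone.

Compound 1 (`COc1ccc(-c2[nH]c3ccc(OC)cc3c2C=O)cc1`) gives 260 nM in a functional assay on MDA-MB-231 cells (Homo sapiens) for antiproliferative activity, with a stated time of 4 days; on this read-out lower numbers stand for stronger inhibition and higher numbers for weaker inhibition
Compound 2 (`COc1ccc(-c2[nH]c3ccc(F)cc3c2C=O)cc1`) gives 540 nM in this assay
Compound 3 (`COc1ccc(-c2[nH]c3cc(Cl)c(C)cc3c2C=O)cc1`) gives 26 nM in this assay

Compound 3 has the lowest number of the three, beyond the scatter from both others. Compound 4 (`COc1ccc(-c2[nH]c3ccc(C)cc3c2C=O)cc1`) has hydrogen in place of chloro on an aromatic carbon, ortho to a methyl group (hydrogen in place of chloro on an aromatic carbon). Among the compounds with values here, the only measured step (a 2.1-fold higher number from compound 1 to compound 2 (0.32 log units; beyond the scatter)) swaps fluoro for methoxy, so no measured pair isolates the chloro. Still, neither chloro-free compound comes close to compound 3: compound 1 gives 260 nM and compound 2 gives 540 nM here. The expected step in this assay is therefore a clear rise (a 5.8-fold higher number from compound 3 to compound 4 (0.76 log units; beyond the scatter)) in the number. Compound 4 is estimated at 150 nM (expected range 45 nM to 480 nM).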

Compound 4, half-maximal inhibitory concentration: 86 nM
Beside the measured number, compound 4's estimate is 1.7-fold (0.24 log units) above it; measured number inside the range.
By their numbers in this assay, from the lowest: compound 3; then compound 4; then compound 1; then compound 2.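

Taking the chloro away in this assay gives a clear but partial loss (a 3.3-fold higher number from compound 3 to compound 4 (0.52 log units; beyond the scatter)), so this pair isolates the chloro's contribution at the carbon ortho to a methyl group. The methyl alone already gives lower numbers than methoxy (a 3.0-fold lower number from compound 1 to compound 4 (0.48 log units; beyond the scatter)) and fluoro (a 6.3-fold lower number from compound 2 to compound 4 (0.80 log units; beyond the scatter)), so much of compound 3's lead over compounds 1 and 2 does not depend on the chloro. No supporting measurement here explains these steps. Open, from the compounds shown here alone, is how bromo or an amine would fare at the chloro's carbon. Also open, going by these compounds, is whether the chloro would lower the number without the methyl.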